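Changing the Anilide on a Shared Core: An Expected Result

The source may report more compounds than this note shows. Statements on the series, on what has been measured and on what is new or still open speak of the compounds shown alone.

Compound 3 `CCOC(=O)c1cc(-c2ccc(Oc3ccccc3)cc2)nn1Cc1ccc(NC(=O)CCl)cc1` is tested in a functional assay on Z-138 cells (Homo sapiens) for inhibition, read by luminescence and CellTiter-Glo, with a stated time of 72 h (a higher number here means a weaker inhibitor, a lower number a stronger inhibitor), where compound 3 gives 400 nM. That matches compound 1 `CCOC(=O)c1cc(-c2ccc(Oc3ccccc3)cc2)nn1Cc1cccc(NC(=O)CCl)c1`, which in this assay gives 400 nM; the step of no change at the digits printed from compound 1 to compound 3 (within the scatter) shows that moving the anilide to a different ring position leaves the number unchanged. Compound 2 `C/C=C/C(=O)Nc1cccc(Cn2nc(-c3ccc(Oc4ccccc4)cc3)cc2CO)c1` gives 5700 nM, a far higher number, but it differs from compound 1 in two places at once, so its weaker result cannot be tied to either change alone. Compound 4 `C/C=C/C(=O)Nc1cccc(Cn2nc(-c3ccc(Oc4ccccc4)cc3)cc2C(=O)OCC)c1` differs from compound 3 by 3-(((prop-1-en-1-yl)carbonyl)amino)phenyl in place of 4-(((chloromethyl)carbonyl)amino)phenyl on a saturated chain carbon bound to an aromatic nitrogen. Only the ring-position step has a clean precedent; the amide swap has none, and compound 2 hints at a loss. The step of a 5.0-fold higher number from compound 3 to compound 4 (0.70 log units; beyond the scatter) is therefore expected to be a loss. Compound 4 is estimated at 2000 nM, within a range from 500 nM to 8000 nM.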

Compound 4, half-maximal inhibitory concentration: 8900 nM
The estimate for compound 4 lay 4.5-fold (0.65 log units) below the measured number; the measured number lies above the stated range.
By their numbers in this assay, from the lowest: compounds 1 and 3 (each within the scatter of the next); then compounds 2 and 4 (each within the scatter of the next).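

On the carbonyl carbon, prop-1-en-1-yl in place of chloromethyl gives a 22-fold higher number from compound 1 to compound 4 (1.35 log units; beyond the scatter) in this assay, so this end of the anilide matters, whereas the ring position alone did not. The step that also moves the anilide, a 22-fold higher number from compound 3 to compound 4 (1.35 log units; beyond the scatter), is of the same size. With prop-1-en-1-yl present, ethoxycarbonyl in place of hydroxymethyl on an aromatic carbon gives a 1.6-fold higher number from compound 2 to compound 4 (0.19 log units; within the scatter), so the two compounds cannot be told apart.

From the compounds shown here alone, whether a plain methyl or a dimethylaminomethyl group on that carbonyl carbon would give a number nearer that of compound 1 stays open. No measurement here explains the large step.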